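Methoxy to chloro on the distal aryl of compound 3

A few compounds are considered here, and "the series" means these few. Any claim that something is new, unique, unknown or untested is made for them only; others in the source may bear on it.

Measured compounds, growth inhibition on NCI-H226 cells:
compound 1 `COc1cc(/C=C/C(=O)c2cccc(-n3cc(-c4ccccc4)[nH]c3=O)c2)ccc1O` gives 2600 nM
compound 2 `O=C(/C=C/c1cccc(O)c1)c1cccc(-n2cc(-c3ccc(Cl)cc3)[nH]c2=O)c1` gives 2310 nM
compound 3 `COc1ccc(-c2cn(-c3cccc(C(=O)/C=C/c4ccc(O)c(OC)c4)c3)c(=O)[nH]2)cc1` gives 4100 nM

In a functional assay on NCI-H226 cells (Homo sapiens) for inhibition (on this read-out lower numbers stand for stronger inhibition of growth and higher numbers for weaker inhibition of growth), compound 3 stands at the highest of the three numbers, yet its gaps to compound 1 and to compound 2 are both within the scatter, so no order among the three can be claimed. Among the measured compounds shown here, the one step that connects measured compounds, a 1.6-fold higher number from compound 1 to compound 3 (0.20 log units; within the scatter), shows that adding methoxy to the distal aryl ring of compound 1 moved the number by no more than the scatter allows.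

Compound 4 `COc1cc(/C=C/C(=O)c2cccc(-n3cc(-c4ccc(Cl)cc4)[nH]c3=O)c2)ccc1O` differs from compound 3 in one place: chloro in place of methoxy on an aromatic carbon. For the measured compounds named here, no measured pair shows this exchange directly. Compound 2 carries the same 4-chlorophenyl group, but its other aryl ring lacks the methoxy of compound 3, so its value can be read only as showing that chloro in that position is compatible with a number near those of compound 1 and compound 3. With nothing pointing to a change beyond the scatter, compound 4 is expected to stay close to compound 3, with a 1.4-fold lower number from compound 3 to compound 4 (0.14 log units; within the scatter) as the estimated step. For compound 4 the estimate in this assay is 3000 nM, expected to fall between 1300 nM and 7000 nM.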

Compound 4, concentration for 50% growth inhibition: 2770 nM
For compound 4 the middle estimate is 1.1-fold (0.03 log units) above the measured one, and the stated range covers the measured number.
By their numbers in this assay, from the lowest: compounds 2, 1, 4 and 3 (each within the scatter of the next).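

In this assay the exchange of 4-methoxyphenyl to 4-chlorophenyl now has a direct pair, with a 1.5-fold lower number from compound 3 to compound 4 (0.17 log units; within the scatter) at this position para to a large group. Setting a 1.1-fold higher number from compound 1 to compound 4 (0.03 log units; within the scatter) alongside a 1.6-fold higher number from compound 1 to compound 3 (0.20 log units; within the scatter) gives hydrogen, methoxy and chloro at this position on the same remainder of the molecule, and no step among the three lies beyond the scatter, so this small set gives no ranking of them. With the 4-chlorophenyl group held constant, the change of 3-hydroxyphenyl to 4-hydroxy-3-methoxyphenyl on the double-bonded chain carbon gives a 1.2-fold higher number from compound 2 to compound 4 (0.08 log units; within the scatter) and so adds a second site where one exchange stays within the scatter.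

Going by these compounds, whether an amine, a carboxylic acid or a longer chain at the para position of this aromatic ring would take the number beyond the scatter remains open. No measurement is at hand that bears on why these four numbers lie so close together.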